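Varying the Aryl Tail of Phosphoserine Ester Agonists

This account rests on a few compounds, and the source may have more. Where it says the series, first, only, none or still open, it means among the compounds named here.

Three compounds have been measured:
compound 1 `CCCCCCCCCCCOc1ccccc1CCC(=O)OCCCOP(=O)(O)OC[C@H](N)C(=O)O`, 0.04
compound 2 `N[C@@H](COP(=O)(O)OCCCOC(=O)CCc1ccccc1OCCCCOc1ccccc1)C(=O)O`, 0.033
compound 3 `N[C@@H](COP(=O)(O)OCCCOC(=O)CCc1ccccc1OCc1cccc(Oc2ccccc2Cl)c1)C(=O)O`, 0.069

These are read in an assay on cells for activation of probable G-protein coupled receptor 34 (Mus musculus), with a stated time of 1 h; a higher number here means a larger maximal response, a lower number a smaller maximal response. Compound 3 gives the largest of the three numbers, yet its gaps to compound 1 and to compound 2 are both within the usual scatter, so the three stand level. Within the data shown here, the one measured step, a number 0.0070 lower from compound 1 to compound 2 (within the scatter), is likewise within the scatter.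

Compound 4 `CCc1ccc(Oc2cccc(COc3ccccc3CCC(=O)OCCCOP(=O)(O)OC[C@H](N)C(=O)O)c2)cc1` differs from compound 3 by 4-ethylphenyl in place of 2-chlorophenyl on an oxygen on an aromatic ring. Among the measured compounds shown here, no measured step touches this oxygen-bound group, and the only tail change seen left the response unmoved, so no step beyond the scatter is expected: a number 0.0010 higher from compound 3 to compound 4 (within the scatter). Compound 4 is estimated at 0.07, between 0.03 and 0.12.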

Compound 4, intrinsic activity: the largest response reached, as a fraction of the reference agonist's: 0.42
Compound 4: middle estimate off by 0.35, on the low side; measured number above the stated range.
By their numbers in this assay, from the lowest: compounds 2, 1 and 3 (each within the scatter of the next); then compound 4.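

In this assay the step a number 0.35 higher from compound 3 to compound 4 (beyond the scatter) is the only one shown that lies beyond the scatter, so the group on this oxygen can move the maximal response, which the earlier tail change did not show. The change itself is small: 4-ethylphenyl has one more heavy atom than 2-chlorophenyl and no chlorine. Nothing available explains the rise.

Going by these compounds, whether it follows from the ethyl group, from losing the chlorine or from where the substituent sits on the ring remains open. A 4-chlorophenyl or a 2-ethylphenyl on the same oxygen would bear on this.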